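Removing one methoxy from the benzyl group of compound 2

A few compounds are considered here, and "the series" means these few. Any claim that something is new, unique, unknown or untested is made for them only; others in the source may bear on it.

Compound 2 `COc1ccc(CNc2nc3cc(N)cc(N)c3nc2-c2ccccc2)cc1OC` serves as the reference. In a functional assay on T47D cells (Homo sapiens) for inhibition, read by sulforhodamine B assay, with a stated time of 48 h (on this read-out lower numbers stand for higher toxicity in this test and higher numbers for lower toxicity in this test), compound 2 gives only a limit, < 100000 nM. Compound 1 `Nc1cc(N)c2nc(-c3ccccc3)c(NCc3ccc(Cl)c(Cl)c3)nc2c1` likewise gives only a limit, < 100000 nM. Compound 3 `CCOC(=O)[C@H](CCC(=O)O)NC(=O)c1ccc(Sc2nc3cc(N)cc(N)c3nc2-c2ccccc2)cc1` also returns only a limit, < 100000 nM. For the measured compounds named here, the single one-site step among measured compounds, a step that the two limits leave unreadable from compound 1 to compound 2, is thus unreadable in size, and the limit of < 100000 nM in this assay, at which 3 of the 3 values shown sit, covers every value shown. Compound 4 `COc1ccc(CNc2nc3cc(N)cc(N)c3nc2-c2ccccc2)cc1` differs from compound 2 by hydrogen in place of methoxy on an aromatic carbon. Going by the values given here, no measured step bears on this change, so no direction or size beyond the scatter can be derived for it. The expected step in this assay is a step that the limit leaves unreadable from compound 2 to compound 4, within scatter. For compound 4 the estimate in this assay is 30000 nM, ranging from 5000 nM to 100000 nM.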

Compound 4, concentration lethal to 50% of the cells: 72400 nM
Beside the measured number, compound 4's estimate is 2.4-fold (0.38 log units) below it; the measured number falls inside the stated range.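

Neither new step, from compound 2 to compound 4 or from compound 1 to compound 4, can be read, since compound 1 and compound 2 give only limits in this assay. The compounds shown leave open the size and direction of either change.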